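Benzyl to Phenyl on a Thiourea Nitrogen: A Small Step

This account rests on a few compounds, and the source may have more. Where it says the series, first, only, none or still open, it means among the compounds named here.

Compound 1 `CC(C)C[C@H](NC(=S)NCc1ccccc1)c1nc2ccccc2[nH]1`: 31200 nM
Compound 2 `CC(C)C[C@H](NC(=S)Nc1ccccc1)c1nc2ccccc2[nH]1`: 29100 nM
Compound 3 `C[C@@H](NC(=S)NCc1ccccc1)c1nc2ccccc2[nH]1`: "not active" (no number reported)

In a functional assay on HeLa cells (Homo sapiens) for cytotoxicity, read by MTT assay (on this read-out higher numbers stand for weaker inhibition and lower numbers for stronger inhibition), compound 1 gives 31200 nM, and compound 2 gives 29100 nM. The change between them is phenyl in place of benzyl on an amide-type nitrogen, and it made a 1.1-fold lower number from compound 1 to compound 2 (0.03 log units; within the scatter). In this assay compound 3 gives "not active" (no number reported), with no number given. The difference between the core of compound 1 and the core of compound 3 is not broken down here. Compound 4 `C[C@@H](NC(=S)Nc1ccccc1)c1nc2ccccc2[nH]1` stands to compound 3 as compound 2 stands to compound 1: the change is phenyl in place of benzyl on an amide-type nitrogen, at the same place. Because the earlier step was a 1.1-fold lower number from compound 1 to compound 2 (0.03 log units; within the scatter), the step from compound 3 to compound 4 in this assay is expected to be small as well, and since compound 3 gave no number, compound 4 may also give none. Compound 4 is expected at about 60000 nM in this assay, estimated between 20000 nM and 200000 nM.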

Compound 4, half-maximal inhibitory concentration: 12400 nM
Compound 4: middle estimate off by 4.8-fold (0.68 log units), on the high side, and the stated range ends above it.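

In this assay, among the compounds shown here, compound 3 carries no number, so no step to compound 4 can be read. The compounds shown leave open how phenyl in place of benzyl acts on this smaller core, and no supporting evidence bears on the result.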